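The source may hold more compounds than are shown below. What is called first, only, known or untested is meant among the compounds shown, and "the series" means these compounds.

Compound 1 `COC(=O)C1=C(C)N=C(C)/C(=C(/O)OC)C1c1c(F)cccc1Cl`: 7.59 nM
Compound 2 `COC(=O)C1=C(C)N=C(C)/C(=C(\O)OC)C1c1ccccc1Cl`: 2.19 nM
Compound 3 `COC(=O)C1=C(C)N=C(C)/C(=C(\O)OC)C1c1c(Cl)cccc1Cl`: 1.91 nM

These three compounds share one core and were all measured in a functional assay (muscle tissue) with Cavia porcellus as the target; a higher number here means that more compound is needed for the effect, a lower number that less compound is needed. Among them compound 2 gives the second highest number: compound 3 sits nearest, and a 1.1-fold lower number from compound 2 to compound 3 (0.06 log units; within the scatter), while compound 1 gives a higher number than compound 2, a gap beyond the scatter. Compound 4 `COC(=O)C1=C(C)N=C(C)/C(=C(\O)OC)C1c1cccc(Cl)c1Cl` is not yet measured. It differs from compound 2 in one place: chloro in place of hydrogen on an aromatic carbon. Among the compounds with values here, the only measured step of the same kind, chloro in place of hydrogen on an aromatic carbon, is the step from compound 2 to compound 3, which stayed within the scatter. On that basis the change in this assay is expected to be small, a 1.0-fold lower number from compound 2 to compound 4 (0.02 log units; within the scatter), in no clear direction. Compound 4 is therefore estimated at 2.1 nM, with a likely range from 0.8 nM to 5.5 nM.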

Compound 4, half-maximal effective concentration: 19.1 nM
Compound 4: middle estimate off by 9.1-fold (0.96 log units), on the low side; measured number outside the range, above it.
By their numbers in this assay, from the lowest: compounds 3 and 2 (each within the scatter of the next); then compound 1; then compound 4.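

In this assay a chloro group in place of hydrogen does not have one fixed outcome: making the 2,6-dichlorophenyl group gives a 1.1-fold lower number from compound 2 to compound 3 (0.06 log units; within the scatter) while making the 2,3-dichlorophenyl group gives an 8.7-fold higher number from compound 2 to compound 4 (0.94 log units; beyond the scatter) in the same series. With two chloro groups in both compounds, 2,3-dichlorophenyl in place of 2,6-dichlorophenyl gives a 10-fold higher number from compound 3 to compound 4 (1.00 log units; beyond the scatter) and so, in this small set, placement matters more than the added chloro itself. As far as these compounds go, whether a fluoro, methyl or methoxy group on that same aromatic carbon would behave like chloro stays open. No available data explain why the number rises.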